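Chain Extension on a Chromone Ether Side Chain

The source may report more compounds than this note shows. Statements on the series, on what has been measured and on what is new or still open speak of the compounds shown alone.

Of the compounds shown here, two have been measured. Compound 1 `COc1c(OCCCCN2CCN(C)CC2)cc(O)c2c(=O)cc(-c3ccc(F)cc3)oc12` gives 3860 nM in a functional assay on MCF7 cells (Homo sapiens) for cytotoxicity, read by MTT assay, with a stated time of 72 h; on this read-out lower numbers stand for stronger inhibition and higher numbers for weaker inhibition. Compound 2 `O=c1cc(-c2ccccc2)oc2c(OCCCN3CCCC3)c(OCc3ccccc3)cc(O)c12` gives 2230 nM in this assay, and the two values sit within the usual scatter of each other, so neither can be set apart from the other. Compound 3 `O=c1cc(-c2ccccc2)oc2c(OCCCCN3CCCC3)c(OCc3ccccc3)cc(O)c12` differs from compound 2 by (pyrrolidin-1-yl)methyl in place of pyrrolidin-1-yl on a saturated chain carbon, three bonds along the chain from an oxygen on an aromatic ring. Within the data shown here, no measured pair shows the effect of such a lengthening, so the expected step from compound 2 to compound 3 is a 1.0-fold lower number from compound 2 to compound 3 (0.01 log units; within the scatter), with no change beyond the scatter anticipated. Compound 3 is therefore estimated at 2200 nM, between 1100 nM and 4500 nM.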

Compound 3, half-maximal inhibitory concentration: 1890 nM
Beside the measured number, compound 3's estimate is 1.2-fold (0.07 log units) above it, within the range that was stated.
By their numbers in this assay, from the lowest: compounds 3, 2 and 1 (each within the scatter of the next, the first and the last beyond it).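

Among these compounds, changing 3-(pyrrolidin-1-yl)propyl to 4-(pyrrolidin-1-yl)butyl gives the first direct reading of chain length at this position, and in this assay it produces a 1.2-fold lower number from compound 2 to compound 3 (0.07 log units; within the scatter). On this evidence, the two chain lengths cannot be told apart at this position. Nothing available bears on why the read-out stays within the scatter.

The compounds shown leave open whether a shorter 2-(pyrrolidin-1-yl)ethyl chain or a longer 5-(pyrrolidin-1-yl)pentyl chain would move the number beyond the scatter. They also leave open whether a morpholine in place of the pyrrolidine at the chain end would do so.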